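The compounds below may be only part of what the source reports. "The series", "measured", "known", "first", "only" and "open" are said of these compounds alone.

In a functional assay on NCI-H441 cells (Homo sapiens) for antiproliferative activity, with a stated time of 24 h (on this read-out higher numbers stand for weaker inhibition and lower numbers for stronger inhibition), three compounds have been measured so far. Compound 1 (`CN(C)c1ccc(/C=C2\CNC/C(=C\c3ccc(N(C)C)cc3)C2=O)cc1`) gives 101000 nM, compound 2 (`OC1/C(=C/c2ccccc2F)CNC/C1=C\c1ccccc1F`) gives 124000 nM, and compound 3 (`O=C(O)COCC(=O)N1C/C(=C\c2ccccc2F)C(=O)/C(=C/c2ccccc2F)C1`) gives 310000 nM. Compound 3 therefore has the highest number of the three, which makes it the weakest inhibitor here, and its gaps to the other two lie beyond the scatter.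

Compound 4 (`O=CN1C/C(=C\c2ccccc2F)C(=O)/C(=C/c2ccccc2F)C1`) has not yet been measured. It differs from compound 3 by one change, hydrogen in place of (carboxymethoxy)methyl on a carbonyl carbon.

Going by the values given here, no measured pair of compounds shows this change on its own, so the evidence is indirect. Compound 3 gives 310000 nM. Compound 1 at 101000 nM and compound 2 at 124000 nM both lack the (carboxymethoxy)methyl group, and both lie lower than compound 3, although they differ from it in other ways too. In this assay, a small move towards stronger inhibition is therefore expected, estimated as a 2.2-fold lower number from compound 3 to compound 4 (0.35 log units; beyond the scatter). For compound 4, the estimated value is 140000 nM, with an expected range of 50000 nM to 350000 nM.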

Compound 4, half-maximal inhibitory concentration: 49000 nM
Compound 4: the middle estimate sits 2.9-fold (0.46 log units) above what was measured; the whole stated range lies above it.
By their numbers in this assay, from the lowest: compound 4; then compounds 1 and 2 (each within the scatter of the next); then compound 3.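

In this assay, the step at this position is clear: with the rest of the molecule unchanged, putting hydrogen in place of (carboxymethoxy)methyl on the carbonyl carbon gives a 6.3-fold lower number from compound 3 to compound 4 (0.80 log units; beyond the scatter), a modest change that lies beyond the usual scatter. Going by these compounds alone, this is the first direct reading of the change, and it shows that the position is not indifferent to what it carries and that the whole (carboxymethoxy)methyl group can go without any loss of inhibition. Nothing measured here explains why the number falls.

A single step cannot show which part of the departing group matters: its acid end, its ether oxygen or simply its length. A small methyl on the same carbonyl carbon, or a chain ending in an amine, would help to separate these possibilities.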